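The compounds below may be only part of what the source reports. "The series", "measured", "known", "first", "only" and "open" are said of these compounds alone.

Measured so far in an ADME assay on HEK-293T cells (Homo sapiens) for inhibition, read by CCK-8 assay, with a stated time of 48 h, tested at 20 uM; a higher number here means more inhibition of growth at the concentration tested, a lower number less inhibition of growth:

Compound 1, `COc1ccc(Cc2nnc(NC(=O)/C(C#N)=C/c3ccccc3OS(=O)(=O)c3ccc(Cl)cc3)s2)cc1`, gives 34%.
Compound 2, `COc1ccc(Cc2nnc(NC(=O)/C(C#N)=C/c3ccccc3OS(=O)(=O)c3ccc(F)cc3)s2)cc1`, gives 6%.
Compound 3, `N#C/C(=C\c1ccccc1OS(=O)(=O)c1ccc(Cl)cc1)C(=O)Nc1nnc(Cc2ccc(Cl)cc2)s1`, gives 14%.

Compound 1 and compound 2 share a core and differ only at one spot: fluoro in place of chloro on an aromatic carbon. That single exchange makes a difference of a number 28 percentage points lower from compound 1 to compound 2 (beyond the scatter) in this assay. Compound 3 carries a different core, and how its core differs from that of compound 1 is counted as chloro in place of methoxy on an aromatic carbon; on that exchange the number moves by a number 20 percentage points lower from compound 1 to compound 3 (beyond the scatter). Compound 3 thus stands between its two neighbours, and its gap to compound 2 is within the scatter, so no order between those two can be claimed.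

Compound 4, `N#C/C(=C\c1ccccc1OS(=O)(=O)c1ccc(F)cc1)C(=O)Nc1nnc(Cc2ccc(Cl)cc2)s1`, has not yet been measured in this assay. It arises from compound 3 by fluoro in place of chloro on an aromatic carbon. Going by the values given here, this is the same change as the one from compound 1 to compound 2, made at the same kind of place, only on the other core. Because the earlier exchange gave a number 28 percentage points lower from compound 1 to compound 2 (beyond the scatter), a move in the same direction is expected for compound 4, though the number for compound 3 is already low and leaves less room to fall, so the expected step is a number 9 percentage points lower from compound 3 to compound 4 (within the scatter). On that basis compound 4 is estimated to give 5% in this assay, most likely between -8% and 18%.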

Compound 4, percent growth inhibition at one concentration: 14%
Beside the measured number, compound 4's estimate is 9 percentage points below it, within the range that was stated.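

In this assay, carrying the change from 4-chlorophenyl to 4-fluorophenyl onto the core of compound 3 gives no change at the digits printed from compound 3 to compound 4 (within the scatter), so the step seen on the core of compound 1 does not repeat there: the same change on two cores in this assay, a number 28 percentage points lower (beyond the scatter) from compound 1 to compound 2 and no change at the digits printed (within the scatter) from compound 3 to compound 4, 28 percentage points apart, beyond the scatter of two such steps. The other exchange, chloro in place of methoxy on an aromatic carbon, gives a number 8 percentage points higher from compound 2 to compound 4 (within the scatter) when read on the two fluoro compounds, and it likewise differs from its earlier counterpart: the same change on two cores in this assay, a number 20 percentage points lower (beyond the scatter) from compound 1 to compound 3 and a number 8 percentage points higher (within the scatter) from compound 2 to compound 4, 28 percentage points apart, beyond the scatter of two such steps. These four compounds therefore show that, in this small set, the size of a step depends on the group present at the other place, so a step measured on one core cannot simply be transferred to the other, but they do not show why this happens or whether it extends to any other core.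

Going by these compounds, it remains open whether a bromo or a methyl group in place of the chloro or fluoro on the sulfonyl-bearing phenyl would behave as it does on the core of compound 1 or as it does on the core of compound 3. The same question stands for an amine or a carboxylic acid in place of the methoxy or chloro group on the other aromatic ring.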